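A few compounds are considered here, and "the series" means these few. Any claim that something is new, unique, unknown or untested is made for them only; others in the source may bear on it.

Compound 1 `CCOC(=O)c1cnc(N2CCN(Cc3ccccc3C#N)CC2)nc1Oc1c(C)cc(-c2ccc(C#N)cc2)cc1C` in an ADME assay on MT4 cells (Homo sapiens) for cytotoxicity, read by MTT assay, with a stated time of 4 days (on this read-out lower numbers stand for higher toxicity in this test and higher numbers for lower toxicity in this test), gives > 125000 nM, which is a limit of the assay and not a number.
Compound 2 `CCOC(=O)c1cnc(N2CCN(Cc3cccc(C(F)(F)F)c3)CC2)nc1Oc1c(C)cc(-c2ccc(C#N)cc2)cc1C` in this assay gives > 125000 nM, again a limit of the assay.
Compound 3 `CCOC(=O)c1cnc(N2CCN(Cc3ccc(Br)cc3)CC2)nc1Oc1c(C)cc(-c2ccc(C#N)cc2)cc1C` in this assay gives > 125000 nM, also a limit of the assay.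

Compound 3 therefore stands where the whole set stands: the limit of > 125000 nM in this assay, at which 3 of the 3 values shown sit. None of the steps among the measured compounds can be read, since each joins two limits: a step that the two limits leave unreadable from compound 1 to compound 2, a step that the two limits leave unreadable from compound 1 to compound 3 and a step that the two limits leave unreadable from compound 2 to compound 3. The group on the saturated chain carbon bound to the amine nitrogen in the ring has thus been varied across these compounds without any of the measurements leaving the limit.

Compound 4 `CCOC(=O)c1cnc(N2CCN(Cc3cccc([N+](=O)[O-])c3)CC2)nc1Oc1c(C)cc(-c2ccc(C#N)cc2)cc1C` differs from compound 3 in the same place: 3-nitrophenyl in place of 4-bromophenyl on a saturated chain carbon bound to an amine nitrogen in a ring. All three measured steps bear on this change in that they swap the aryl group at exactly this position, and all three are unreadable. Nothing in the data points to a readable step in this assay, so the expected change is a number no higher from compound 3 to compound 4 (the limit leaves the size open), that is, none beyond the scatter. The estimate for compound 4 in this assay is therefore 125000 nM, with a range from 50000 nM to 300000 nM, and it is most likely that only a limit is reported again.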

Compound 4, half-maximal cytotoxic concentration: > 125000 nM
Compound 4 gave a limit, no number; the forecaster's own chance of this, stated with the estimate: 85%; the middle value lies on the limit itself.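

In this assay the steps to compound 4 from compound 1, compound 2 and compound 3 each join two limits, so none of them can be read. The set remains at a single limit: the limit of > 125000 nM in this assay, at which 4 of the 4 values shown sit. The compounds shown leave open whether any aryl group on the saturated chain carbon bound to an amine nitrogen in a ring would give a number rather than a limit.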